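The compounds below may be only part of what the source reports. "The series", "measured", "known", "first", "only" and "open" are said of these compounds alone.

Compound 1 `CN/C(C)=N/c1cc(-c2ccccc2)nn1-c1ccccc1` and compound 2 `C/C(=N\c1cc(-c2ccccc2)nn1-c1ccccc1)N(C)C` share one core and differ only by methyl in place of hydrogen on an amine nitrogen. In a functional assay on NCI-H661 cells (Homo sapiens) for inhibition, read by MTT assay, with a stated time of 72 h (on this read-out higher numbers stand for weaker inhibition of growth and lower numbers for stronger inhibition of growth), compound 1 gives > 50000 nM, which is a limit of the assay and not a number. In this assay compound 2 gives 35100 nM. That value is the only number shown for the series. The step of an at least 1.4-fold lower number from compound 1 to compound 2 (0.15 log units; that floor lies within the scatter) rests on the limit of > 50000 nM in this assay, at which 1 of the 2 values shown sits, and therefore says little about how large a change within this series can be.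

Compound 3 `CN(C)/C(=N/c1cc(-c2ccccc2)nn1-c1ccccc1)c1ccccc1` differs from compound 2 by phenyl in place of methyl on a carbon with a double bond to nitrogen. No measured step concerns a phenyl in place of methyl, and the single step shown does not bear on this change. The expectation for this assay is accordingly no step beyond the scatter. Compound 3 is expected to give 35000 nM, with a range from 9000 nM to 140000 nM. The step this estimate means is a 1.0-fold lower number from compound 2 to compound 3 (0.00 log units; within the scatter). Compound 2 sits close to the limit of this assay, and a limit rather than a number is also possible for compound 3.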

Compound 3, concentration for 50% growth inhibition: 46700 nM
Beside the measured number, compound 3's estimate is 1.3-fold (0.13 log units) below it, and the stated range covers the measured number.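

At the position on a carbon with a double bond to nitrogen, phenyl in place of methyl gives a 1.3-fold higher number from compound 2 to compound 3 (0.12 log units; within the scatter) in this assay. For the compounds shown here, this is the first step read between two numbers, as the earlier step rested on a limit, and it shows that this position carries either methyl or phenyl with no change beyond the scatter. Compound 2 and compound 3 therefore cannot be ranked against each other, and neither group stands out at this position, where the window for reading any change remains narrow: the limit of > 50000 nM in this assay, at which 1 of the 3 values shown sits.

As far as these compounds go, what an amine, a carboxylic acid or a longer chain would do on this carbon stays open, and with it the question of whether any group at this position can move the number beyond the scatter. Also open, from the compounds shown here alone, is how the series would respond to a group larger than methyl on the amine nitrogen, such as ethyl, or to a substituent such as a methoxy group on the phenyl rings of the shared core.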